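Aryl swap on the saturated ring carbon: cytotoxicity notes

A few compounds are considered here, and "the series" means these few. Any claim that something is new, unique, unknown or untested is made for them only; others in the source may bear on it.

Compound 1 `COc1cc(C2C(C(=O)Nc3ccc(Cl)cc3)=C(C)NC(C)=C2C(=O)Nc2ccc(Cl)cc2)ccc1O` and compound 2 `CC1=C(C(=O)Nc2ccc(Cl)cc2)C(c2cccc(Cl)c2)C(C(=O)Nc2ccc(Cl)cc2)=C(C)N1` share one core, while compound 3 `COc1ccc(NC(=O)C2=C(C)NC(=O)NC2c2ccc(O)c(OC)c2)cc1` is built on a different core; the difference between the two cores is not broken down here. Compound 4 `COc1ccc(NC(=O)C2=C(C)NC(=O)NC2c2cccc(Cl)c2)cc1` is the counterpart of compound 3 and has not yet been measured. In an ADME assay on Vero cells (Chlorocebus sabaeus) for cytotoxicity, read by sulforhodamine B assay, with a stated time of 3 days (a higher number here means that more compound is tolerated, a lower number that less compound is tolerated), compound 1 gives 250 ug/mL, compound 2 gives 12 ug/mL and compound 3 gives 8 ug/mL. Compound 3 and compound 2 lie within the scatter of each other, and both lie beyond it from compound 1.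

The change 3-chlorophenyl in place of 4-hydroxy-3-methoxyphenyl on a saturated ring carbon made a 21-fold lower number from compound 1 to compound 2 (1.32 log units; beyond the scatter). In compound 3 the same kind of change, (3-chlorophenyl in place of 4-hydroxy-3-methoxyphenyl on a saturated ring carbon), sits on a six-membered non-aromatic ring with 2 nitrogen, next to the ring nitrogen and next to the ring atom that bears a large group, two ring bonds from the ring atom that bears a methyl group; in compound 1 the ring has 1 nitrogen, and the carbon is next to two ring atoms that each bear a (4-chlorophenyl)carbamoyl group and two ring bonds from two ring atoms that each bear a methyl group.

The step of a 21-fold lower number from compound 1 to compound 2 (1.32 log units; beyond the scatter) is the only basis for an expectation. A lower number in this assay is expected for compound 4. Because compound 3 already gives 8 ug/mL, the step expected for compound 4, a 2.7-fold lower number from compound 3 to compound 4 (0.43 log units; beyond the scatter), is taken as smaller than the earlier one. The estimate for compound 4 is 3 ug/mL, expected to fall between 1 ug/mL and 12 ug/mL.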

Compound 4, half-maximal cytotoxic concentration: 254 ug/mL
Beside the measured number, compound 4's estimate is 85-fold (1.93 log units) below it; the whole stated range lies below it.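

In this assay, 3-chlorophenyl in place of 4-hydroxy-3-methoxyphenyl on a saturated ring carbon gives a 32-fold higher number from compound 3 to compound 4 (1.50 log units; beyond the scatter), and the step runs opposite to the one on the other core: the same change on two cores in this assay, a 21-fold lower number (1.32 log units; beyond the scatter) from compound 1 to compound 2 and a 32-fold higher number (1.50 log units; beyond the scatter) from compound 3 to compound 4, 660-fold (2.82 log units) apart, beyond the scatter of two such steps

In this series, then, the outcome of this aryl swap on one core gives no guide to its direction on the other, and the change cannot be treated as transferable between them. The comparison rests on a single pair per core, and the two cores differ in more than one place, so it does not show which difference between them turns the step around.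

Open, from the compounds shown here alone, is whether another group on the same saturated ring carbon, such as a phenyl ring bearing an amine or a carboxylic acid, would follow the pair on the core of compound 1 or the pair on the core of compound 3. Also open, going by these compounds, is how a phenyl ring carrying only the hydroxy group or only the methoxy group would behave on each core.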